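Hydrazone aryl swap on a shared urea core: compound 4

A few compounds are considered here, and "the series" means these few. Any claim that something is new, unique, unknown or untested is made for them only; others in the source may bear on it.

Compound 1 `CN(C)CCn1cnnc1-c1cc(Oc2ccc(NC(=O)N/N=C/c3cc(C(C)(C)C)cc(C(C)(C)C)c3O)cc2F)ccn1` gives 980 nM in a functional assay on A549 cells (Homo sapiens) for cytotoxicity, read by MTT assay, with a stated time of 72 h; a higher number here means a weaker inhibitor, a lower number a stronger inhibitor. Compound 2 `COc1ccc(/C=N/NC(=O)Nc2ccc(Oc3ccnc(-c4nncn4CCN(C)C)c3)c(F)c2)c(OC)c1` gives 2820 nM in this assay. Compound 3 `CN(C)CCn1cnnc1-c1cc(Oc2ccc(NC(=O)N/N=C/c3ccccc3O[N+](=O)[O-])cc2F)ccn1` gives 1200 nM in this assay.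

Among these three numbers compound 3 stands second highest; its nearest neighbour is compound 1, which differs from it within the scatter, and its furthest is compound 2, which lies beyond the scatter above it. Among the compounds with values here, the one step measured so far with a single change at this position, a 2.4-fold lower number from compound 2 to compound 3 (0.37 log units; beyond the scatter), shows that exchanging the aryl group on the carbon double-bonded to nitrogen can move the number by a modest amount.

Compound 4 `CN(C)CCn1cnnc1-c1cc(Oc2ccc(NC(=O)N/N=C/c3c(O)ccc4ccccc34)cc2F)ccn1` carries 2-hydroxynaphthalen-1-yl in place of 2-(nitrooxy)phenyl on a carbon with a double bond to nitrogen. Within the data shown here, no measured step exchanges a 2-(nitrooxy)phenyl for a 2-hydroxynaphthalen-1-yl, so the only guide is that compounds 1, 2 and 3 all fall within a narrow band in this assay, and that compound 1 and compound 3 differ within the scatter. A step no larger than the scatter is therefore expected, a 1.2-fold lower number from compound 3 to compound 4 (0.08 log units; within the scatter). Compound 4 is expected to give about 1000 nM in this assay, with a range from 400 nM to 2500 nM.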

Compound 4, half-maximal inhibitory concentration: 880 nM
The estimate for compound 4 lay 1.1-fold (0.06 log units) above the measured number; the measured number falls inside the stated range.
By their numbers in this assay, from the lowest: compounds 4, 1 and 3 (each within the scatter of the next); then compound 2.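

The exchange of 2-(nitrooxy)phenyl for 2-hydroxynaphthalen-1-yl on a carbon with a double bond to nitrogen gives a 1.4-fold lower number from compound 3 to compound 4 (0.13 log units; within the scatter) in this assay and so stays inside the scatter, even though the entering group brings a second six-membered aromatic ring of carbon only and 1 hydrogen-bond donor, and the leaving group had 3 hydrogen-bond acceptors. Measured against 2,4-dimethoxyphenyl, the same entering group gives a 3.2-fold lower number from compound 2 to compound 4 (0.51 log units; beyond the scatter) and, together with a 2.4-fold lower number from compound 2 to compound 3 (0.37 log units; beyond the scatter) as the earlier step, this sets compound 2 apart from both compound 3 and compound 4 by steps beyond the scatter, so two aryl groups of very different make-up read alike at this position while 2,4-dimethoxyphenyl does not. No supporting measurement is available that would account for these steps.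

The compounds shown leave open what the hydroxyl of 2-hydroxynaphthalen-1-yl contributes, a question that a plain naphthalen-1-yl at this position would address. They also leave open whether an aryl group carrying an amine or a carboxylic acid on this carbon would stay in the same band.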